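The source may hold more compounds than are shown below. What is called first, only, known or untested is meant among the compounds shown, and "the series" means these compounds.

Measured compounds in a functional assay on a cell-free system (plasma) with sterol O-acyltransferase, Soat (Rattus norvegicus) as the target; a lower number here means that less compound is needed, a higher number that more compound is needed for the effect:

Compound 1, `Cc1cc(C)c(NC(=O)N(Cc2ccc(-c3n[nH]c(C)n3)cc2)C2CCCCCC2)c(C)c1`: compound 1 gives > 1 mg/kg, which is a limit of the assay and not a number.

Compound 2, `Cc1cc(C)c(NC(=O)N(Cc2cccc(-c3nnn(C)n3)c2)C2CCCCCC2)c(C)c1`: compound 2 gives < 1 mg/kg, likewise a limit and not a number.

Among the measured compounds shown here, compound 1 therefore stands only at a limit in this assay, and the one other value shown is also a limit, so the two compounds together give no measured step at all. The limit of compound 1 is the limit of > 1 mg/kg in this assay, at which 1 of the 2 values shown sits, while compound 2 sits at the limit of < 1 mg/kg in this assay, at which 1 of the 2 values shown sits; what the pair shows is only that the two lie on different sides of the same boundary.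

Compound 3, `Cc1cc(C)c(NC(=O)N(Cc2ccc(-c3cn[nH]c3)cc2)C2CCCCCC2)c(C)c1`, has not yet been measured. It differs from compound 1 in one place: 1H-pyrazol-4-yl in place of 5-methyl-1H-1,2,4-triazol-3-yl on an aromatic carbon

For the measured compounds named here, with no measured step to lean on, the expected size of the step from compound 1 to compound 3 in this assay is small, and its direction is open; the estimate is a number no higher from compound 1 to compound 3 (the limit leaves the size open), which is not expected to go beyond the scatter. Compound 3 is therefore estimated at 1 mg/kg, within a range from 0.3 mg/kg to 4 mg/kg.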

Compound 3, dose for half-maximal effect: > 1 mg/kg
Compound 3 ended at the assay's limit; the forecaster's own chance of this, stated with the estimate: 55%; the middle value lies on the limit itself.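

In this assay compound 3 gives > 1 mg/kg, a limit of the assay and not a number. Compound 1 also stands at a limit, so no step can be read between compound 1 and compound 3. The compounds shown leave open whether 1H-pyrazol-4-yl and 5-methyl-1H-1,2,4-triazol-3-yl differ at all in this assay.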